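From 2-Methylphenyl to 4-Chlorophenyl on a Shared Core

A few compounds are considered here, and "the series" means these few. Any claim that something is new, unique, unknown or untested is made for them only; others in the source may bear on it.

Compound 2 `Cc1ccccc1Nc1nc(N)nc(CSc2nc3ccccc3[nH]2)n1` was examined in an ADME assay on Vero cells (Chlorocebus sabaeus) for cytotoxicity, read by resazurin assay, with a stated time of 3 days; a lower number here means that less compound is tolerated, a higher number that more compound is tolerated. In this assay compound 2 gives > 2000 ug/mL, which is a limit of the assay rather than a number, placing it at the limit of > 2000 ug/mL in this assay, at which 1 of the 2 values shown sits. Compound 1 `Cc1ccc(Nc2nc(N)nc(CSc3nc4ccccc4[nH]3)n2)cc1` has "not determined" (no result reported) in this assay. Compound 3 `Nc1nc(CSc2nc3ccccc3[nH]2)nc(Nc2ccc(Cl)cc2)n1` differs from compound 2 by 4-chlorophenyl in place of 2-methylphenyl on a nitrogen on an aromatic ring. For the measured compounds named here, no measured step covers this change, so the data give no size for it. The shift from compound 2 to compound 3 is expected to be a number no higher from compound 2 to compound 3 (the limit leaves the size open), none beyond the scatter. Compound 3 is therefore estimated at 2000 ug/mL, within 1000 ug/mL to 4000 ug/mL, most likely reported again only as a limit.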

Compound 3, half-maximal cytotoxic concentration: 1500 ug/mL
Beside the measured number, compound 3's estimate is 1.3-fold (0.12 log units) above it; the measured number falls inside the stated range.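

In this assay, 4-chlorophenyl in place of 2-methylphenyl on a nitrogen on an aromatic ring gives the first single number among the compounds shown, with an at least 1.3-fold lower number from compound 2 to compound 3 (0.12 log units; that floor lies within the scatter). Compound 2 stands only at a limit of the assay: the limit of > 2000 ug/mL in this assay, at which 1 of the 3 values shown sits. Going by these compounds, the step is thus a floor, and its true size remains unknown.

The steps to compound 1 cannot be read. On these data alone, how a carboxylic acid or a morpholine in place of the 4-chlorophenyl would read in this assay remains open.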